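Between Amino and Dimethylamino: One Methyl Removed

This account rests on a few compounds, and the source may have more. Where it says the series, first, only, none or still open, it means among the compounds named here.

Two compounds share one core. Compound 1 `NCC1OCc2c1ccc(O)c2O` carries an amino group on the chain; in an assay on isolated protein (Oryctolagus cuniculus) for binding affinity to Adrenergic receptor alpha-1 (Homo sapiens) (a lower number here means a stronger inhibitor, a higher number a weaker inhibitor), compound 1 gives 9800 nM. Compound 2 `CN(C)CC1OCc2c1ccc(O)c2O` carries a dimethylamino group there instead, and in this assay compound 2 gives 1160 nM. The step of an 8.4-fold lower number from compound 1 to compound 2 (0.93 log units; beyond the scatter) connects them. Among the two measured numbers, compound 2 stands lowest, with compound 1 the nearest and higher.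

Compound 3 `CNCC1OCc2c1ccc(O)c2O` sits between the two: hydrogen in place of methyl on an amine nitrogen. Among the compounds with values here, only the step from compound 1 to compound 2 bears on this change, since it altered the same amine nitrogen in the opposite direction, from amino to dimethylamino; compound 3 takes one methyl away again. Because that step, an 8.4-fold lower number from compound 1 to compound 2 (0.93 log units; beyond the scatter), was modest, removing one methyl is expected to give back part of it, so the number for compound 3 is expected to lie above that of compound 2 yet under that of compound 1. Compound 3 is therefore estimated at 3200 nM, with a range from 1200 nM to 8500 nM. That expected step is written as a 2.8-fold higher number from compound 2 to compound 3 (0.44 log units; beyond the scatter).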

Compound 3, inhibition constant: 1970 nM
Compound 3: middle estimate off by 1.6-fold (0.21 log units), on the high side; low and high end bracket the measured number.
By their numbers in this assay, from the lowest: compounds 2 and 3 (each within the scatter of the next); then compound 1.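

In this assay, placing a single methyl on the amine nitrogen of compound 1 already gives a clear change, a 5.0-fold lower number from compound 1 to compound 3 (0.70 log units; beyond the scatter), so the methylamino group of compound 3 is enough to separate it from the amino compound. The second methyl adds nothing that can be resolved at this position: the difference between dimethylamino and methylamino is a 1.7-fold higher number from compound 2 to compound 3 (0.23 log units; within the scatter), which leaves compound 2 and compound 3 indistinguishable here, even though the earlier comparison of compound 1 and compound 2 could not show which of the two methyls carried the change. No measurement shown here explains why the first methyl on this nitrogen counts and the second cannot be told from it.

Going by these compounds, whether this level persists with a larger group on the same nitrogen, such as an ethyl, an isopropyl or a benzyl group, remains open, as does the effect of a third methyl, which would give a trimethylammonium group. On these data alone, a longer chain between the nitrogen and the shared core is also open, so it is unknown whether the same methyl steps would appear there.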